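This account rests on a few compounds, and the source may have more. Where it says the series, first, only, none or still open, it means among the compounds named here.

Compound 3 `COc1cc2c(Oc3ccc(NC(=O)c4cc(-c5ccccc5)nc5ccc(F)cc45)cc3F)ccnc2cc1OCCCN1CCCCC1` gives the lowest number among the three compounds measured in a functional assay on NCI-H460 cells (Homo sapiens) for cytotoxicity, read by MTT assay, with a stated time of 72 h (on this read-out higher numbers stand for weaker inhibition and lower numbers for stronger inhibition), at 32 nM; compound 1 `COc1cc2c(Oc3ccc(NC(=O)c4cc(-c5ccccc5)nc5ccccc45)cc3F)ccnc2cc1OCCCN1CCCCC1` gives 110 nM and compound 2 `COc1cc2c(Oc3ccc(NC(=O)c4cc(-c5ccc(Cl)c(Cl)c5)nc5ccccc45)cc3F)ccnc2cc1OCCCN1CCCC1` gives 400 nM. Compound 4 `COc1ccc(-c2cc(C(=O)Nc3ccc(Oc4ccnc5cc(OCCCN6CCCCC6)c(OC)cc45)c(F)c3)c3cc(F)ccc3n2)cc1` differs from compound 3 by methoxy in place of hydrogen on an aromatic carbon, para to a large group, so that the phenyl becomes a 4-methoxyphenyl. Within the data shown here, the only single-point step measured, a 3.4-fold lower number from compound 1 to compound 3 (0.54 log units; beyond the scatter), concerns a different ring and does not bear on substitution of this phenyl; compound 2 carries a dichlorophenyl but also a different amine, so its value cannot be separated into parts. Among the measured compounds shown here, with no directly relevant step, a change within the scatter or at most a modest one is expected, a 1.4-fold higher number from compound 3 to compound 4 (0.15 log units; within the scatter). Compound 4 is therefore estimated at 45 nM, with a range from 12 nM to 170 nM.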

Compound 4, half-maximal inhibitory concentration: 240 nM
Compound 4: the middle estimate sits 5.3-fold (0.73 log units) below what was measured, outside the stated range (above it).
By their numbers in this assay, from the lowest: compound 3; then compound 1; then compounds 4 and 2 (each within the scatter of the next).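

In this assay, the phenyl position proves sensitive to substitution: methoxy in place of hydrogen, para to a large group, gives a 7.5-fold higher number from compound 3 to compound 4 (0.88 log units; beyond the scatter) and this step lies beyond the scatter. Among these compounds, it is the first clean reading on this ring, as the earlier step concerned a different ring. No evidence at hand accounts for this change.

Whether this step is specific to methoxy remains open, as 4-methoxyphenyl is the only single change shown at this position. Fluoro, hydroxy or dimethylamino at the same place could show whether other groups give a similar step.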